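A flat series meets a new side chain

This account rests on a few compounds, and the source may have more. Where it says the series, first, only, none or still open, it means among the compounds named here.

In a functional assay on MCF7 cells (Homo sapiens) for inhibition, read by MTT assay, with a stated time of 3 days (a lower number here means a stronger inhibitor, a higher number a weaker inhibitor), compound 1 `COc1cc(-c2nc3ccccc3s2)ccc1OCC(=O)NNC(O)CN(C)CC(=O)O` gives 1960 nM and compound 2 `CC[C@H](C)[C@H](NCC(=O)NNC(=O)COc1ccc(-c2nc3ccccc3s2)cc1OC)C(=O)O` gives 1710 nM while compound 3 `COc1cc(-c2nc3ccccc3s2)ccc1OCC(=O)NNC(=O)CN(C(C)=O)[C@@H](CS)C(=O)O` gives 1750 nM as its reading. Compound 3 thus stands within the scatter of both others. Compound 4 `CCOC(=O)[C@H](CS)NCC(=O)NNC(=O)COc1ccc(-c2nc3ccccc3s2)cc1OC` differs from it at one place (1-(ethoxycarbonyl)-2-sulfanylethyl)amino in place of acetyl(1-carboxy-2-sulfanylethyl)amino on a saturated chain carbon bound to a carbonyl carbon with (1-(ethoxycarbonyl)-2-sulfanylethyl)amino in place of acetyl(1-carboxy-2-sulfanylethyl)amino on a saturated chain carbon bound to a carbonyl carbon. For the measured compounds named here, the one measured step at this place is a 1.0-fold higher number from compound 2 to compound 3 (0.01 log units; within the scatter) and it stays within the scatter, yet no measured compound carries the entering group. The expected step is therefore a 1.0-fold higher number from compound 3 to compound 4 (0.01 log units; within the scatter) and none beyond the scatter is expected in this assay here. For compound 4 the estimate is 1800 nM with an expected range from 1000 nM to 3200 nM for now.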

Compound 4, half-maximal inhibitory concentration: 2880 nM
Compound 4: middle estimate off by 1.6-fold (0.20 log units), on the low side, within the range that was stated.
By their numbers in this assay, from the lowest: compounds 2, 3, 1 and 4 (each within the scatter of the next).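

Replacing acetyl(1-carboxy-2-sulfanylethyl)amino with (1-(ethoxycarbonyl)-2-sulfanylethyl)amino gives a 1.6-fold higher number from compound 3 to compound 4 (0.22 log units; within the scatter) in this assay and, on an amine nitrogen, 1-(ethoxycarbonyl)-2-sulfanylethyl in place of 1-carboxy-2-methylbutyl gives a 1.7-fold higher number from compound 2 to compound 4 (0.23 log units; within the scatter) on the same scale. The earlier compounds shown here all carry a free carboxylic acid on this chain, whereas compound 4 shows that an ethyl ester there also stays within the scatter. No supporting evidence bears on these readings. Still open, on these data alone, is whether a phenyl ring or a longer chain at this place would give a step beyond the scatter.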